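Fluoro for Methyl on the Aromatic Nitrogen Substituent

This account rests on a few compounds, and the source may have more. Where it says the series, first, only, none or still open, it means among the compounds named here.

Three measured compounds share one core and differ only in the group on an aromatic nitrogen. Compound 1 `Cc1cccc(-n2cc(COc3cccc(NC(=O)Nc4ccc(Cl)c(C(F)(F)F)c4)c3)nn2)c1` carries a 3-methylphenyl and in a functional assay on HepG2 cells (Homo sapiens) for inhibition, read by MTT assay, with a stated time of 72 h (on this read-out higher numbers stand for weaker inhibition and lower numbers for stronger inhibition), compound 1 gives 7270 nM. Compound 2 `Cc1ccc(-n2cc(COc3cccc(NC(=O)Nc4ccc(Cl)c(C(F)(F)F)c4)c3)nn2)cc1`, with a 4-methylphenyl, gives 5430 nM in this assay, and compound 3 `O=C(Nc1cccc(OCc2cn(-c3ccccc3F)nn2)c1)Nc1ccc(Cl)c(C(F)(F)F)c1`, with a 2-fluorophenyl, gives 1520 nM. Compound 2 therefore stands second highest of the three numbers: the step of a 1.3-fold lower number from compound 1 to compound 2 (0.13 log units; within the scatter) lies within the scatter, whereas a 3.6-fold lower number from compound 2 to compound 3 (0.55 log units; beyond the scatter) and a 4.8-fold lower number from compound 1 to compound 3 (0.68 log units; beyond the scatter) both lie beyond it.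

Compound 4 `O=C(Nc1cccc(OCc2cn(-c3ccc(F)cc3)nn2)c1)Nc1ccc(Cl)c(C(F)(F)F)c1` has not yet been measured. It differs from compound 2 by fluoro in place of methyl on an aromatic carbon. The nearest guide is the step of a 3.6-fold lower number from compound 2 to compound 3 (0.55 log units; beyond the scatter), which also replaced methyl with fluoro, though compound 3 carries a 2-fluorophenyl rather than a 4-fluorophenyl, so its modest gain transfers only in part. Because the two methyl compounds separate only by a 1.3-fold lower number from compound 1 to compound 2 (0.13 log units; within the scatter), a small lowering is expected, with the step of a 1.6-fold lower number from compound 2 to compound 4 (0.19 log units; within the scatter) likely near the edge of the scatter. Compound 4 is estimated at 3500 nM, within a range of 1200 nM to 9000 nM.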

Compound 4, half-maximal inhibitory concentration: 1350 nM
For compound 4 the middle estimate is 2.6-fold (0.41 log units) above the measured one; the measured number falls inside the stated range.
By their numbers in this assay, from the lowest: compounds 4 and 3 (each within the scatter of the next); then compounds 2 and 1 (each within the scatter of the next).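

In this assay, among these compounds, the step of a 4.0-fold lower number from compound 2 to compound 4 (0.60 log units; beyond the scatter) is the first direct reading of fluoro in place of methyl at a single place on the ring, para to a large group, and the wider step a 5.4-fold lower number from compound 1 to compound 4 (0.73 log units; beyond the scatter) points the same way. The lower number is not tied to the 2-fluorophenyl of compound 3, for the step of a 1.1-fold lower number from compound 3 to compound 4 (0.05 log units; within the scatter) leaves the two fluorophenyl compounds indistinguishable, and in this small set both sit lower than both methylphenyl compounds. Nothing at hand explains why the fluorophenyl compounds give the lower numbers.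

Still open, going by these compounds, is whether this gain belongs to fluoro in particular or would also appear with chloro, methoxy or an amine at the same place. Also open, on these data alone, is whether a 3-fluorophenyl would match the other two fluorophenyl compounds.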